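The source may hold more compounds than are shown below. What is called first, only, known or untested is meant among the compounds shown, and "the series" means these compounds.

Of the compounds shown here, three of a shared core have been measured in an assay on Huh-7 cells for agonist activity at Bile acid receptor (Homo sapiens), read by a luciferase reporter; a lower number here means that less compound is needed, a higher number that more compound is needed for the effect. Compound 1 `CC(C)c1onc(-c2c(Cl)cccc2Cl)c1COc1ccc(-c2nc3ccc(C(=O)O)cc3n2CC2CCCCC2)c(F)c1` gives 7.8 nM, and compound 3 `CC(C)c1onc(-c2c(Cl)cccc2Cl)c1COc1ccc(-c2nc3ccc(C(=O)O)cc3n2CC2CCCCC2)c(Cl)c1` gives 7.6 nM; the step of a 1.0-fold lower number from compound 1 to compound 3 (0.01 log units; within the scatter) shows that swapping the halogen on that aromatic carbon changes nothing that can be trusted. Compound 2 `CC(C)c1onc(-c2c(Cl)cccc2Cl)c1COc1ccc(-c2nc3ccc(C(=O)O)cc3n2C2CC2)cc1` gives 16.5 nM, the highest of the three numbers: more of it is needed than of compound 1 or compound 3, and both gaps lie beyond the scatter.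

Compound 4 `CC(C)c1onc(-c2c(Cl)cccc2Cl)c1COc1ccc(-c2nc3ccc(C(=O)O)cc3n2C(C)C)cc1` differs from compound 2 in one place: isopropyl in place of cyclopropyl on an aromatic nitrogen. The ring of the cyclopropyl is opened into an isopropyl, with the same count of carbon atoms and no change in donors, acceptors or charge. Among the compounds with values here, none of the measured steps touches this position. Within the data shown here, the only measured step, between compound 1 and compound 3, concerns a halogen elsewhere, and compounds 1 and 3 carry a different group on the ring nitrogen than compound 2, so no measured pair isolates what an isopropyl does there.

With nothing to lean on, the expectation for compound 4 is a step of a 1.0-fold lower number from compound 2 to compound 4 (0.01 log units; within the scatter) that stays within the scatter. Compound 4 is therefore estimated at 16 nM, with a range from 7 nM to 40 nM.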

Compound 4, half-maximal effective concentration: 3.39 nM
Beside the measured number, compound 4's estimate is 4.7-fold (0.67 log units) above it; measured number outside the range, below it.
By their numbers in this assay, from the lowest: compound 4; then compounds 3 and 1 (each within the scatter of the next); then compound 2.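

Within the data shown here, the step of a 4.9-fold lower number from compound 2 to compound 4 (0.69 log units; beyond the scatter) in this assay is the first measured change at this aromatic nitrogen, and it shows that the position responds to the choice of group, even when the heavy-atom count, hydrogen-bond donors, hydrogen-bond acceptors and net charge all stay the same. Among these compounds, of the features compared here, the one that differs is the three-membered ring, which cyclopropyl has and isopropyl lacks, and the open group is the one that needs less compound for the effect. The data shown contain no measurement that explains why this small structural change moves the number beyond the scatter, so the step stands as an observation only.

The compounds shown leave open how a tert-butyl or a cyclobutyl on the same nitrogen would read, and so whether the gain belongs to isopropyl alone or extends to other small carbon groups, with or without a ring. They also leave open whether isopropyl would give a similar step alongside the fluoro or chloro of compound 1 and compound 3, as neither of those compounds has a partner that differs from it only at this nitrogen.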